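Benzyl Ring Swap on an Adenosine-Type Scaffold

A few compounds are considered here, and "the series" means these few. Any claim that something is new, unique, unknown or untested is made for them only; others in the source may bear on it.

The measured compounds and their values in a functional assay on K562 cells (Homo sapiens) for antiproliferative activity, with a stated time of 72 h; on this read-out higher numbers stand for weaker inhibition and lower numbers for stronger inhibition:
Compound 1, `OC[C@H]1O[C@@H](n2cnc3c(NCc4ccccc4F)ncnc32)[C@H](O)[C@@H]1O`: compound 1 gives 33200 nM.
Compound 2, `OC[C@H]1O[C@@H](n2cnc3c(NCc4ccc(F)cc4)ncnc32)[C@H](O)[C@@H]1O`: compound 2 gives 2700 nM.
Compound 3, `OC[C@H]1O[C@@H](n2cnc3c(NCc4ccc(Cl)c(Cl)c4)ncnc32)[C@H](O)[C@@H]1O`: compound 3 gives 10800 nM.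

Compound 2 stands lowest of the three numbers in this assay, separated from both neighbours beyond the scatter: a 4.0-fold higher number from compound 2 to compound 3 (0.60 log units; beyond the scatter), and a 12-fold lower number from compound 1 to compound 2 (1.09 log units; beyond the scatter). Compound 4, `COc1cc(CNc2ncnc3c2ncn3[C@@H]2O[C@H](CO)[C@@H](O)[C@H]2O)cc(OC)c1`, has not been measured. It differs from compound 2 in one place: 3,5-dimethoxyphenyl in place of 4-fluorophenyl on a saturated chain carbon bound to a nitrogen on an aromatic ring.

Going by the values given here, two measured steps bear on this change, since each swaps the aryl group on the same saturated chain carbon. Both steps away from 4-fluorophenyl gave higher numbers, one modest (a 4.0-fold higher number from compound 2 to compound 3 (0.60 log units; beyond the scatter)) and one large (read backwards from a 12-fold lower number from compound 1 to compound 2 (1.09 log units; beyond the scatter)). Neither involves a methoxy-bearing ring, so the size of the step for compound 4 is uncertain, but a rise of modest size in this assay is expected. Compound 4 is therefore estimated at 9000 nM, within 3000 nM to 30000 nM, an expected step of a 3.3-fold higher number from compound 2 to compound 4 (0.52 log units; beyond the scatter).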

Compound 4, half-maximal inhibitory concentration: > 166000 nM
Compound 4 was reported as a limit (the forecaster's own chance of this, stated with the estimate: 10%); at least 18-fold (1.26 log units) between middle value and limit.
By their numbers in this assay, from the lowest: compound 2; then compound 3; then compound 1. At a limit, above all of these: compound 4.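

In this assay compound 4 is reported only as a limit, not as a number: the limit of > 166000 nM in this assay, at which 1 of the 4 values shown sits. Swapping 4-fluorophenyl for 3,5-dimethoxyphenyl gives the largest step seen at this position so far, with an at least 61-fold higher number from compound 2 to compound 4 (1.78 log units; beyond the scatter). The new ring also sits beyond both other rings, with an at least 15-fold higher number from compound 3 to compound 4 (1.18 log units; beyond the scatter) and an at least 5.0-fold higher number from compound 1 to compound 4 (0.69 log units; beyond the scatter), so a change of aryl group alone on this saturated chain carbon moves the number further than the halogen-bearing rings had shown.

Going by these compounds, whether a single methoxy group on the ring would act like the two in 3,5-dimethoxyphenyl stays open, and so does the true size of these steps. Also open, on these data alone, is how a ring carrying an amine or a carboxylic acid, or a longer chain in place of this saturated chain carbon, would read in this assay.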